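Notes on a repeated chloro-for-hydrogen change

This account rests on a few compounds, and the source may have more. Where it says the series, first, only, none or still open, it means among the compounds named here.

Compound 1 `COc1ccc(Cl)cc1C(=O)Nc1ccc(Cl)cc1O` and compound 2 `COc1ccc(Cl)cc1C(=O)Nc1cc(Cl)c(Cl)cc1O` share one core; compound 3 `COc1cc(Cl)ccc1C(=S)Nc1cc(Cl)ccc1O` and compound 4 `COc1cc(Cl)ccc1C(=S)Nc1cc(Cl)c(Cl)cc1O` share another. How the core of compound 3 differs from that of compound 1 is not broken down here. In a functional assay on HepG2 cells (Homo sapiens) for cytotoxicity, with a stated time of 24 h (on this read-out higher numbers stand for weaker inhibition and lower numbers for stronger inhibition), compound 1 gives 51300 nM and compound 2 gives 2980 nM; the change between them is chloro in place of hydrogen on an aromatic carbon, and the step is a 17-fold lower number from compound 1 to compound 2 (1.24 log units; beyond the scatter). In this assay compound 3 gives 8490 nM, a higher number than compound 2 and a lower number than compound 1.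

Compound 4 is not yet measured. It differs from compound 3 by chloro in place of hydrogen on an aromatic carbon. This is the same kind of change as that from compound 1 to compound 2, but the surroundings differ: in compound 2 the entering chloro is meta to a large group and para to a hydroxy group, whereas in compound 4 it is meta to a hydroxy group and para to a large group. For the measured compounds named here, the expectation for compound 4 rests on the one measured step, a 17-fold lower number from compound 1 to compound 2 (1.24 log units; beyond the scatter), with the changed surroundings as the main uncertainty. Compound 4 is expected at 700 nM in this assay, within a range from 200 nM to 2500 nM. That estimated step is a 12-fold lower number from compound 3 to compound 4 (1.08 log units; beyond the scatter).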

Compound 4, half-maximal inhibitory concentration: 3160 nM
Compound 4: middle estimate off by 4.5-fold (0.65 log units), on the low side, outside the stated range (above it).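

In this assay the chloro-for-hydrogen change goes with a lower number on the second core as well, the new step being a 2.7-fold lower number from compound 3 to compound 4 (0.43 log units; beyond the scatter), so the direction is the same in the two pairs shown. The size of the step does not carry over from one core to the other: the same change on two cores in this assay, a 17-fold lower number (1.24 log units; beyond the scatter) from compound 1 to compound 2 and a 2.7-fold lower number (0.43 log units; beyond the scatter) from compound 3 to compound 4, 6.4-fold (0.81 log units) apart, beyond the scatter of two such steps. Two pairs do not show whether this gap comes from the cores themselves, from the different surroundings of the entering chloro, or from both, and they establish no rule for the size of the step on any further core.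

From the compounds shown here alone, whether a bromo group, a methyl group or an amine on the same aromatic carbon would go the same way as chloro remains open. Also open, going by these compounds, is which part of the difference between the two cores goes with the smaller step, a question that would need pairs differing in one place at the core.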